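This account rests on a few compounds, and the source may have more. Where it says the series, first, only, none or still open, it means among the compounds named here.

Working notes on the series, read in an ADME assay on HeLa cells (Homo sapiens) for cytotoxicity, read by sulforhodamine B assay, with a stated time of 48 h, tested at 10 uM; a lower number here means less inhibition, a higher number more inhibition at the concentration tested (going by the name of the read-out). Compound 1 `COc1nc2ccc(Br)cc2cc1C(c1ccccc1)n1cc(-c2ccccc2)nn1` gives 13.9%. Compound 2 `CCCCc1cn(C(c2ccccc2)c2cc3cc(Br)ccc3nc2OC)nn1` gives -2.87%, and compound 3 `CCCCCCCCc1cn(C(c2ccccc2)c2cc3cc(Br)ccc3nc2OC)nn1` gives 0.1%. Among these three numbers compound 3 stands second highest: its nearest neighbour is compound 2, within the scatter, while compound 1 sits higher by a margin beyond the scatter. The steps run a number 16.8 percentage points lower from compound 1 to compound 2 (beyond the scatter) and a number 13.8 percentage points lower from compound 1 to compound 3 (beyond the scatter), both modest, whereas a number 3 percentage points higher from compound 2 to compound 3 (within the scatter) stays inside the scatter.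

Compound 4 `COc1nc2ccc(Br)cc2cc1C(c1ccccc1)n1cc(CO)nn1` differs from compound 3 in one place: hydroxy in place of heptyl on a saturated chain carbon bound to an aromatic carbon. Of the measured steps only a number 3 percentage points higher from compound 2 to compound 3 (within the scatter) bears on this change, since it is the one that also alters the group on the saturated chain carbon bound to the aromatic carbon, and it did not move beyond the scatter. Among the measured compounds shown here, no measured step brings in a hydroxy, so the present numbers give no ground for a move beyond the scatter in either direction in this assay. The expected step is therefore a number 1.9 percentage points higher from compound 3 to compound 4 (within the scatter), lying within the scatter. Compound 4 is accordingly estimated at 2%, with a range from -10% to 14%.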

Compound 4, a percentage reported as inhibition, at one concentration (the size of the read-out at that concentration, not a potency): 0.25%
Beside the measured number, compound 4's estimate is 1.8 percentage points above it; the measured number falls inside the stated range.
By their numbers in this assay, from the lowest: compounds 2, 3 and 4 (each within the scatter of the next); then compound 1.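

Within this assay the hydroxy group in place of heptyl gives a number 0.2 percentage points higher from compound 3 to compound 4 (within the scatter) and in place of propyl gives a number 3.1 percentage points higher from compound 2 to compound 4 (within the scatter) and so, on the saturated chain carbon bound to an aromatic carbon, a chain ending in hydroxy reads the same as the butyl and octyl chains. Replacing phenyl on the aromatic carbon with hydroxymethyl gives a number 13.7 percentage points lower from compound 1 to compound 4 (beyond the scatter) and thus matches the modest drops already seen with butyl and octyl, which leaves compound 1 alone above the other three compounds, with none of them going against this. The series now holds three different non-ring groups at this position that cannot be told apart here, and no available measurement offers an explanation for the separate standing of phenyl.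

Open, going by these compounds, is whether that standing belongs to phenyl itself or to rings at this position more widely, as a cyclohexyl or pyridyl group would test. Also open, on these data alone, is whether an amine or a carboxylic acid at the end of the chain would leave the reading within the scatter of compound 4 or move it.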